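A fluorophenyl swap on the aromatic nitrogen

The compounds below may be only part of what the source reports. "The series", "measured", "known", "first", "only" and "open" are said of these compounds alone.

In a physicochemical assay for solubility, at pH 7.5 (a higher number here means a more soluble compound, a lower number a less soluble compound), compound 2 (`CC(C)(C)c1cc(NC(=O)Nc2cccc(Cl)c2Cl)n(-c2ccc([N+](=O)[O-])cc2)n1`) gives 66 ug/mL and stands lowest of the two measured compounds, under compound 1 (`CC(C)(C)c1cc(NC(=O)Nc2cccc(Cl)c2Cl)n(-c2cccc(N)c2)n1`) with 594 ug/mL as its number. Compound 3 (`CC(C)(C)c1cc(NC(=O)Nc2cccc(Cl)c2Cl)n(-c2cccc(F)c2)n1`) carries 3-fluorophenyl in place of 4-nitrophenyl on an aromatic nitrogen of the shared core (3-fluorophenyl in place of 4-nitrophenyl on an aromatic nitrogen). Among the compounds with values here, the one measured step at this place, 4-nitrophenyl in place of 3-aminophenyl, is modest but beyond the scatter (a 9.0-fold lower number from compound 1 to compound 2 (0.95 log units; beyond the scatter)). Within the data shown here, compound 3 keeps neither of those two groups, and no measured compound carries fluorine, so that step shows how large a change at this place can be but gives no direction for the new group. In this assay the expected step is therefore small (a 1.4-fold higher number from compound 2 to compound 3 (0.13 log units; within the scatter)) and is not expected to leave the scatter, although the uncertainty is wide. Compound 3 is estimated at 90 ug/mL (range 30 ug/mL to 270 ug/mL).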

Compound 3, solubility: 17 ug/mL
Beside the measured number, compound 3's estimate is 5.3-fold (0.72 log units) above it; the whole stated range lies above it.
By their numbers in this assay, from the lowest: compound 3; then compound 2; then compound 1.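

Swapping 4-nitrophenyl for 3-fluorophenyl on the aromatic nitrogen was not a neutral change in this assay: it gave a 3.9-fold lower number from compound 2 to compound 3 (0.59 log units; beyond the scatter), so this place also responds to a change that involves neither amino nor nitro. The sharper contrast is fluoro in place of amino on an aromatic carbon, a change at one ring atom that gave a 35-fold lower number from compound 1 to compound 3 (1.54 log units; beyond the scatter), and this step is graded large where the other two are modest. Nothing available bears on what lies behind these differences.

The compounds shown leave open how much of the step from compound 2 to compound 3 follows the group and how much follows its place on the ring, as 4-nitrophenyl and 3-fluorophenyl differ in both. They also leave open where a hydroxyl or a carboxylic acid in place of the fluoro would fall relative to compound 1.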